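The source may hold more compounds than are shown below. What is called first, only, known or untested is meant among the compounds shown, and "the series" means these compounds.

In a functional assay on PC-3 cells (Homo sapiens) for inhibition, read by MTT assay, with a stated time of 48 h, tested at 10 uM (a higher number here means more inhibition of growth at the concentration tested, a lower number less inhibition of growth), three compounds have been measured so far:

- compound 1 `Cc1cc(=O)c2c(O)cc(OCc3ccc([N+](=O)[O-])cc3)c([C@H]3CCN(C)C[C@H]3O)c2o1` gives 23%
- compound 2 `Cc1cc(=O)c2c(O)c(CN3CCCC3)c(O)c([C@H]3CCN(C)C[C@H]3O)c2o1` gives 10%
- compound 3 `Cc1cc(=O)c2c(O)c(CN(C)CC(=O)O)c(O)c([C@H]3CCN(C)C[C@H]3O)c2o1` gives 20%

Compound 3 lies within the scatter of both other compounds, so the numbers do not set it apart from either one.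

Compound 4 `Cc1cc(=O)c2c(O)c(CN(C(C)C)C(C)C)c(O)c([C@H]3CCN(C)C[C@H]3O)c2o1` has not yet been measured. It carries diisopropylamino in place of (carboxymethyl)(methyl)amino on a saturated chain carbon bound to an aromatic carbon, a swap that can be counted out as diisopropylamino in place of (carboxymethyl)(methyl)amino on a saturated chain carbon bound to an aromatic carbon.

For the measured compounds named here, only one measured step changes the group at this place. That step is a number 10 percentage points higher from compound 2 to compound 3 (within the scatter), and it replaced pyrrolidin-1-yl with (carboxymethyl)(methyl)amino. Going by the values given here, compound 1 offers no step here. With so little evidence, a small downward shift that stays within the scatter is expected, and the estimated step is a number 5 percentage points lower from compound 3 to compound 4 (within the scatter) in this assay.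

For compound 4 the estimate is 15%, with an expected range from 3% to 30%.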

Compound 4, percent growth inhibition at one concentration: 0%
Beside the measured number, compound 4's estimate is 15 percentage points above it; the measured number lies below the stated range.
By their numbers in this assay, from the lowest: compounds 4, 2, 3 and 1 (each within the scatter of the next, the first and the last beyond it).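

In this assay, the place on a saturated chain carbon bound to an aromatic carbon now shows its first step beyond the scatter (a number 20 percentage points lower from compound 3 to compound 4 (beyond the scatter)), so the choice of amine here can register in this read-out. Diisopropylamino in place of pyrrolidin-1-yl gives a smaller step that stays inside the scatter (a number 10 percentage points lower from compound 2 to compound 4 (within the scatter)), so those two groups are not separated by these numbers. No measurement at hand explains the larger step.

The compounds shown do not reveal whether the step from (carboxymethyl)(methyl)amino to diisopropylamino depends more on losing the carboxylic acid or on gaining the two isopropyl groups. Also open, from the compounds shown here alone, is how a simple dimethylamino group, a morpholine ring, or a carboxylic acid on a longer chain would read at this place.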